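Aryl substituent changes on the shared hydrazone core

The source may hold more compounds than are shown below. What is called first, only, known or untested is meant among the compounds shown, and "the series" means these compounds.

Compound 2 `Cc1ccc(N/N=C2\CCC(C)n3c2ncc(C(=O)O)c3=O)cc1` gives the lowest of the two numbers in a functional assay (mast cells) for inhibition, with Rattus norvegicus as the target (a higher number here means that more compound is needed for the effect, a lower number that less compound is needed), at 280 nM. For the measured compounds named here, its nearest neighbour is compound 1 `CC1CC/C(=N\Nc2ccccc2F)c2ncc(C(=O)O)c(=O)n21`, which in this assay gives 1200 nM; the only measured step is a 4.3-fold lower number from compound 1 to compound 2 (0.63 log units; beyond the scatter). Compound 3 `CNC(=O)c1ccc(N/N=C2\CCC(C)n3c2ncc(C(=O)O)c3=O)cc1` differs from compound 2 by methylcarbamoyl in place of methyl on an aromatic carbon. Going by the values given here, the measured step concerns the same ring but a different group, so it bears only loosely on this change; no measured step covers a methylcarbamoyl group. The expected step is a 1.4-fold higher number from compound 2 to compound 3 (0.15 log units; within the scatter), with wide uncertainty. Compound 3 is therefore estimated at 400 nM, in the range 120 nM to 1300 nM.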

Compound 3, half-maximal effective concentration: 100000 nM
Compound 3: middle estimate off by 250-fold (2.40 log units), on the low side; the measured number lies above the stated range.
By their numbers in this assay, from the lowest: compound 2; then compound 1; then compound 3.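

In this assay, a 360-fold higher number from compound 2 to compound 3 (2.55 log units; beyond the scatter), so this aromatic carbon, para to a large group, is far from indifferent to the group it carries. The earlier change, a 4.3-fold lower number from compound 1 to compound 2 (0.63 log units; beyond the scatter), had shown only a modest shift, and nothing in it hinted at a drop of this size. No evidence on the cause of this loss is at hand. The compounds shown leave open whether the amide as a whole matters or only part of it. An acetyl group, a methoxy group, an amine or a carboxylic acid at this carbon could stay close to compound 2 or fall with compound 3.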